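This account rests on a few compounds, and the source may have more. Where it says the series, first, only, none or still open, it means among the compounds named here.

Measured so far in an assay on isolated protein for inhibition of Amine oxidase [flavin-containing] B (Homo sapiens); on this read-out lower numbers stand for stronger inhibition and higher numbers for weaker inhibition:
compound 1 `CC(=O)N1N=C(c2ccc(O)cc2)CC1c1ccccc1Cl`: 89000 nM
compound 2 `COc1ccccc1C1CC(c2ccc(O)cc2)=NN1C(C)=O`: 100000 nM

Compound 2 stands together with compound 1 on this read-out: a 1.1-fold higher number from compound 1 to compound 2 (0.05 log units; within the scatter), so the two numbers cannot be told apart. Compound 3 `COc1ccc(C2CC(c3ccc(O)cc3)=NN2C(C)=O)c(OC)c1` differs from compound 2 by methoxy in place of hydrogen on an aromatic carbon; the newcomer sits meta to a methoxy group and para to a large group. Among the measured compounds shown here, the one measured step, a 1.1-fold higher number from compound 1 to compound 2 (0.05 log units; within the scatter), concerns a methoxy in place of chloro at another place on the same ring and stayed within the scatter, which is the only guide available; no measured step touches the place changed here. Adding a second methoxy is therefore expected to give no step beyond the scatter, with the weak numbers of the pair carried over. Compound 3 is estimated at 100000 nM, range 40000 nM to 250000 nM, an expected step of no change at the digits printed from compound 2 to compound 3 (within the scatter).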

Compound 3, half-maximal inhibitory concentration: 20000 nM
Beside the measured number, compound 3's estimate is 5.0-fold (0.70 log units) above it; the measured number lies below the stated range.
By their numbers in this assay, from the lowest: compound 3; then compounds 1 and 2 (each within the scatter of the next).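

In this assay a methoxy in place of hydrogen, meta to a methoxy group and para to a large group, gives a 5.0-fold lower number from compound 2 to compound 3 (0.70 log units; beyond the scatter), a modest step but the first beyond the scatter in this series. The ring of the shared core therefore responds to substitution at this place, whereas methoxy in place of chloro at the other place gave only a 1.1-fold higher number from compound 1 to compound 2 (0.05 log units; within the scatter) and no readable change. No measurement bears on the reason for this step.

Open, as far as these compounds go, is whether the new methoxy gives this step on its own or only together with the methoxy already on the ring. Also open, from the compounds shown here alone, is whether a hydroxy group, an ethoxy group or an amine at the same place would give a step of similar size.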